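The source may hold more compounds than are shown below. What is called first, only, known or untested is meant among the compounds shown, and "the series" means these compounds.

Measured in a functional assay on cells (Erythrocyte, Rattus norvegicus) for inhibition, read by hemolysis, with a stated time of 1 h; on this read-out lower numbers stand for stronger inhibition and higher numbers for weaker inhibition:
- compound 1, `COc1cc(OC)c(OC)cc1/C=C/C(=O)c1cc(OC(C)=O)ccc1OC(C)=O`: 2.33 ug/mL
- compound 2, `COc1ccc(C(=O)/C=C/c2cc(OC)c(OC)cc2OC)cc1`: 2.18 ug/mL
- compound 3, `COc1cc(OC)c(OC)cc1/C=C/C(=O)c1cc(Cc2ccccc2)cc(Cc2ccccc2)c1`: 2.17 ug/mL

Compound 2 stands second highest of these three numbers. Its nearest neighbour is compound 3 and its furthest is compound 1; both gaps lie within the scatter, so the three numbers cannot be told apart, and none of the three compounds can be called stronger or weaker than another. The shared core of compound 1 carries a different second ring in each case, and the numbers do not move.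

Compound 4, `COc1cc(OC)c(OC)cc1/C=C/C(=O)c1ccc(O)cc1`, is not yet measured. Relative to compound 2 the change is hydrogen in place of methyl on an oxygen on an aromatic ring. Going by the values given here, no measured pair shows this change, so its size is not known from data here. Given that the three measured variations of the second ring all sit together, the expectation for this assay is a step of no size beyond the scatter, in neither direction. The estimated step of a 1.1-fold higher number from compound 2 to compound 4 (0.02 log units; within the scatter) is accordingly close to none. Compound 4 is expected to give 2.3 ug/mL, with a range from 1.2 ug/mL to 4.5 ug/mL.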

Compound 4, half-maximal inhibitory concentration: 2.29 ug/mL
Compound 4: middle estimate off by 1.0-fold (0.00 log units), on the high side; the measured number falls inside the stated range.
By their numbers in this assay, from the lowest: compounds 3, 2, 4 and 1 (each within the scatter of the next).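

In this assay the series now holds its first pair differing in one place: the change from 4-methoxyphenyl to 4-hydroxyphenyl reads as a 1.1-fold higher number from compound 2 to compound 4 (0.02 log units; within the scatter) and stays there, so this step has a measured size rather than an inferred one. At this place on the aromatic ring, a free hydroxy therefore serves as well as methoxy, and the methyl on the oxygen is not required to hold the number. No measurement shown here offers an explanation for this flat result.

From the compounds shown here alone, whether an amine or a carboxylic acid in place of the hydroxy, or a longer chain on the oxygen, would shift the number remains open. One pair also cannot show whether the same change behaves alike on the other aromatic ring.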